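Bromo for iodo on the aryl carbamate of a lactone

This account rests on a few compounds, and the source may have more. Where it says the series, first, only, none or still open, it means among the compounds named here.

Measured compounds:
Compound 1, `C=C1C(=O)OC[C@H]1CCOC(=O)Nc1cccc(Br)c1`: 21800 nM
Compound 2, `C=C1C(=O)OC[C@H]1CCOC(=O)Nc1ccc(I)cc1`: 12800 nM
Compound 3, `C=C1C(=O)OC[C@@H]1CCOC(=O)Nc1ccc(I)cc1`: 12500 nM

In an ADME assay on RAW264.7 cells (Mus musculus) for cytotoxicity, read by MTT assay, with a stated time of 18 h (on this read-out lower numbers stand for higher toxicity in this test and higher numbers for lower toxicity in this test), compound 2 gives the second highest of the three numbers. Its nearest neighbour is compound 3, with a 1.0-fold lower number from compound 2 to compound 3 (0.01 log units; within the scatter), a pair whose two structures are set apart only by the fact that compounds 2 and 3 differ only in the configuration as drawn. Compounds 1 and 2 differ in two places, so their values are only compared as they stand, and they lie within the scatter of each other. Compound 4, `C=C1C(=O)OC[C@H]1CCOC(=O)Nc1ccc(Br)cc1`, is obtained from compound 2 by bromo in place of iodo on an aromatic carbon. Within the data shown here, no measured step changes a halogen alone, so the only guide is that every halogen variant so far sits within the scatter of the others, and no step beyond the scatter is expected. For compound 4 the estimated value in this assay is 16000 nM, between 8000 nM and 32000 nM. This is expected to correspond to a 1.3-fold higher number from compound 2 to compound 4 (0.10 log units; within the scatter).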

Compound 4, half-maximal cytotoxic concentration: 8470 nM
For compound 4 the middle estimate is 1.9-fold (0.28 log units) above the measured one; the range from low to high includes it.
By their numbers in this assay, from the lowest: compounds 4, 3, 2 and 1 (each within the scatter of the next, the first and the last beyond it).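

In this assay, among these compounds, the first step that changes the halogen alone is a 1.5-fold lower number from compound 2 to compound 4 (0.18 log units; within the scatter). Among the compounds shown here, on this aromatic carbon, para to a large group, bromo and iodo therefore cannot be told apart, which the earlier compounds could not show. Nothing given here explains this step.

The compounds shown leave open whether an amine or a carboxylic acid at this place would give a step beyond the scatter. They also leave open whether chloro would stay within it.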